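A few compounds are considered here, and "the series" means these few. Any claim that something is new, unique, unknown or untested is made for them only; others in the source may bear on it.

Measured in a functional assay on MDA-MB-436 cells (Homo sapiens) for antiproliferative activity, read by MTT assay, with a stated time of 48 h; on this read-out higher numbers stand for weaker inhibition and lower numbers for stronger inhibition:
Compound 1 `C=CS(=O)(=O)N1CCN(c2ncnc3sc(-c4ccc(C#N)cc4)cc23)CC1`: 9170 nM
Compound 2 `C=CS(=O)(=O)N1CCN(c2ncnc3sc(-c4cccc5ncccc45)cc23)CC1`: 25900 nM
Compound 3 `C=CS(=O)(=O)N1CCN(c2ncnc3sc(-c4ccnc(Cl)c4)cc23)CC1`: 30100 nM

Compound 3 and compound 2 form the upper pair of numbers, while compound 1 lies lower. The measured steps place compound 3 clearly: a 1.2-fold higher number from compound 2 to compound 3 (0.07 log units; within the scatter), and a 3.3-fold higher number from compound 1 to compound 3 (0.52 log units; beyond the scatter).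

In compound 4 `C=CS(=O)(=O)N1CCN(c2ncnc3sc(-c4cn(C)nc4C(F)(F)F)cc23)CC1`, 1-methyl-3-(trifluoromethyl)-1H-pyrazol-4-yl stands in place of 2-chloropyridin-4-yl on an aromatic carbon, next to the ring sulfur: 1-methyl-3-(trifluoromethyl)-1H-pyrazol-4-yl in place of 2-chloropyridin-4-yl on an aromatic carbon.

All measured steps are swaps at this same place. They comprise a 2.8-fold higher number from compound 1 to compound 2 (0.45 log units; beyond the scatter) and the two above, so the largest swap seen here is modest. Within the data shown here, none of the measured compounds carries a five-membered ring at this place, so the data give no direction for this change. A modest shift either way remains possible, but no step beyond the scatter is the central expectation. The expected step is a 1.4-fold lower number from compound 3 to compound 4 (0.14 log units; within the scatter). Compound 4 is estimated at 22000 nM, with an expected range of 8000 nM to 60000 nM.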

Compound 4, half-maximal inhibitory concentration: 15100 nM
For compound 4 the middle estimate is 1.5-fold (0.16 log units) above the measured one; measured number inside the range.
By their numbers in this assay, from the lowest: compounds 1, 4, 2 and 3 (each within the scatter of the next, the first and the last beyond it).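

In this assay, the first five-membered ring at this place, 1-methyl-3-(trifluoromethyl)-1H-pyrazol-4-yl, cannot be separated from any of the three groups seen before: a 2.0-fold lower number from compound 3 to compound 4 (0.30 log units; within the scatter), a 1.7-fold lower number from compound 2 to compound 4 (0.23 log units; within the scatter) and a 1.6-fold higher number from compound 1 to compound 4 (0.22 log units; within the scatter) all stay within the scatter. Compound 4 therefore bridges a gap without joining either end, since a 3.3-fold higher number from compound 1 to compound 3 (0.52 log units; beyond the scatter) lies beyond the scatter, and a six-membered ring is shown not to be required at this place for a number in this range. No measurement given here accounts for this result.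

With only one five-membered ring shown, the separate contributions of its methyl and trifluoromethyl groups remain open. On these data alone, it is also open whether a pyrazole bearing an amine or a carboxylic acid in place of trifluoromethyl would move the number beyond the scatter in either direction.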